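This account rests on a few compounds, and the source may have more. Where it says the series, first, only, none or still open, it means among the compounds named here.

Three compounds in this set share one core and differ only in the group on the carbonyl carbon bound to the amide-type nitrogen in a ring. Compound 1 is `O=C(c1cccc(F)c1)N1CCN(c2nc(=O)c3cc(C(F)(F)F)cc([N+](=O)[O-])c3s2)CC1`, compound 2 is `CCCC(=O)N1CCN(c2nc(=O)c3cc(C(F)(F)F)cc([N+](=O)[O-])c3s2)CC1` and compound 3 is `O=C(CC1CCCCC1)N1CCN(c2nc(=O)c3cc(C(F)(F)F)cc([N+](=O)[O-])c3s2)CC1`. In an ADME assay on Vero cells (Chlorocebus sabaeus) for cytotoxicity, read by MTT assay, with a stated time of 72 h (a lower number here means that less compound is tolerated, a higher number that more compound is tolerated), compound 1 returns a limit, > 125000 nM, rather than a number. In this assay compound 2 likewise returns only the limit > 125000 nM. In this assay compound 3 also stands at the limit, > 125000 nM, so its position is known only as a bound and not as a value. The three steps among these compounds, a step that the two limits leave unreadable from compound 1 to compound 2, a step that the two limits leave unreadable from compound 1 to compound 3 and a step that the two limits leave unreadable from compound 2 to compound 3, carry no readable size because of the limit of > 125000 nM in this assay, at which 3 of the 3 values shown sit. Compound 4 is `O=C(C1CCC1)N1CCN(c2nc(=O)c3cc(C(F)(F)F)cc([N+](=O)[O-])c3s2)CC1`; it differs from compound 3 in that (cyclobutyl in place of cyclohexylmethyl on a carbonyl carbon). Going by the values given here, none of the measured steps can be read, so they give no direction for this change; all that can be said is that 3-fluorophenyl, propyl and cyclohexylmethyl on that carbonyl carbon each left the compound at the limit. Compound 4 is therefore expected to sit at the same limit, with an expected step of a number no higher from compound 3 to compound 4 (the limit leaves the size open) that means no change beyond the scatter. The estimate for compound 4 in this assay is 125000 nM, expected to lie between 62500 nM and 250000 nM.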

Compound 4, half-maximal cytotoxic concentration: > 125000 nM
Compound 4: a limit, no number; the forecaster's own chance of this, stated with the estimate: 85%; the middle value sits exactly at the limit.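

In this assay compound 4 returns > 125000 nM, which is a limit and not a number. The steps to compound 4 from compound 1, compound 2 and compound 3 therefore cannot be read, because all of these results rest on one bound: the limit of > 125000 nM in this assay, at which 4 of the 4 values shown sit. The compounds shown leave open whether any group on that carbonyl carbon would give a measurable value in this assay.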